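The source may hold more compounds than are shown below. What is called first, only, known or untested is meant among the compounds shown, and "the series" means these compounds.

Working notes on the series, with a physicochemical assay for solubility (on this read-out lower numbers stand for lower solubility and higher numbers for higher solubility), as the read-out. Compound 1 `C[C@H]1C(=O)N(C)C=Cc2cc(C(CO)CO)ccc21` gives >= 209 ug/mL, which is a limit of the assay and not a number. Compound 2 `CCS(=O)(=O)c1ccc2c(c1)C(C)=CN(C)C(=O)[C@@H]2C` gives >= 131 ug/mL, which is also a limit. Compound 2 therefore has no exact value, and no order between the two compounds can be read from these results.

Compound 3 `CCS(=O)(=O)c1ccc2c(c1)C(C(N)=O)=CN(C)C(=O)[C@@H]2C` differs from compound 2 in one place: carbamoyl in place of methyl on a double-bonded ring carbon. Carbamoyl stands in place of methyl on a double-bonded ring carbon of the seven-membered non-aromatic ring, two ring bonds from the ring nitrogen.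

Within the data shown here, no measured pair differs in one place, so no measured step is available to set the size of this one. No step beyond the scatter is expected in this assay, and so no clear direction is expected either. The expected change is a step that the limit leaves unreadable from compound 2 to compound 3, an estimate anchored on the limit for compound 2. For compound 3 the estimated value is 170 ug/mL, with an expected range from 70 ug/mL to 400 ug/mL.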

Compound 3, solubility: 82 ug/mL
Compound 3: middle estimate off by 2.1-fold (0.32 log units), on the high side; low and high end bracket the measured number.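

In this assay, compound 3 gives 82 ug/mL, the only exact number among the compounds shown, so the series now has a measured value to compare against. Carbamoyl in place of methyl on a double-bonded ring carbon, two ring bonds from the ring nitrogen, gives an at least 1.5-fold lower number from compound 2 to compound 3 (0.20 log units; that floor lies within the scatter); the change brings no higher number at this position, but the floor alone does not establish a step beyond the scatter. The true size of the step stays unknown because compound 2 stands at a limit of the assay and not at a number: the limit of >= 131 ug/mL in this assay, at which 1 of the 3 values shown sits.

Open, as far as these compounds go, is how the number moves at this ring carbon with an amine, a carboxylic acid or a longer chain in place of methyl, and whether the outcome tracks the hydrogen-bond donor and acceptor that carbamoyl brings. Also open, from the compounds shown here alone, is whether the same change, made on a compound with an exact starting value, gives a step beyond the scatter.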